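The source may report more compounds than this note shows. Statements on the series, on what has been measured and on what is new or still open speak of the compounds shown alone.

Measured so far:
- compound 1, `CCOC(=O)c1c(-c2ccccc2)nn(-c2ccccc2)c1Cn1cnc2ccccc21`: 35 ug/mL
- compound 2, `CCOC(=O)c1c(-c2ccccc2)nn(-c2ccccc2)c1COCc1c(-c2ccc(F)cc2)nc(N(C)S(C)(=O)=O)nc1C(C)C`: 15 ug/mL

In an assay for inhibition of Alpha amylase (Homo sapiens), with a stated time of 30 min (a higher number here means a weaker inhibitor, a lower number a stronger inhibitor), compound 1 gives 35 ug/mL. This is the highest of the two numbers recorded, so compound 1 is the weaker inhibitor of the pair. Compound 2 gives 15 ug/mL in this assay, a lower number that lies beyond the usual scatter, so compound 2 is the stronger inhibitor of the two. The two compounds share the same core but differ in many places at once, so no single change can be credited for that gap.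

The next compound keeps the core of compound 1 and alters only one point. Compound 3, `CCOC(=O)c1c(-c2ccccc2)nn(-c2ccccc2)c1Cn1c(Cl)nc2ccccc21`, differs from compound 1 in this way: chloro in place of hydrogen on an aromatic carbon. Within the data shown here, no measured pair shows what such a change does here, so the size and direction of the step can only be guessed. A step from compound 1 to compound 3 of about a 1.2-fold lower number from compound 1 to compound 3 (0.07 log units; within the scatter) in this assay is expected, that is, a change within the usual scatter in either direction. Compound 3 is therefore estimated at 30 ug/mL, with a range from 15 ug/mL to 60 ug/mL.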

Compound 3, half-maximal inhibitory concentration: 10 ug/mL
For compound 3 the middle estimate is 3.0-fold (0.48 log units) above the measured one, outside the stated range (below it).
By their numbers in this assay, from the lowest: compounds 3 and 2 (each within the scatter of the next); then compound 1.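

Putting chloro in place of hydrogen on the aromatic carbon between two ring nitrogen atoms gives a 3.5-fold lower number from compound 1 to compound 3 (0.54 log units; beyond the scatter) in this assay and makes compound 3 the stronger inhibitor of this pair. The earlier two compounds differed in many places at once, so their gap could not be tied to any one spot, whereas here the whole change is a single chlorine atom that turns 1H-benzimidazol-1-yl into 2-chloro-1H-benzimidazol-1-yl, and this one position clearly matters for the read-out. Nothing available explains how this one atom produces a step of that size.

A single pair cannot show whether the step belongs to chlorine in particular or whether other groups on the same carbon would do as well, such as fluoro, bromo, methyl, methoxy or an amine. It also leaves open whether chloro would give a step of similar size and direction at other carbons of the benzimidazole group, or on a compound that carries a different group in place of the ethyl ester.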